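From butoxy to ethyl: cytotoxicity notes on compound 4

A few compounds are considered here, and "the series" means these few. Any claim that something is new, unique, unknown or untested is made for them only; others in the source may bear on it.

Measured in a toxicity assay on MDCK cells (Canis lupus familiaris) for cytotoxicity, read by CCK-8 assay, with a stated time of 48 h; a lower number here means that less compound is tolerated, a higher number that more compound is tolerated:
- compound 1 `CCOc1ccc(C(=O)NNc2c(Br)cccc2Br)cc1`: > 100000 nM (a limit)
- compound 2 `CCCOc1ccc(C(=O)NNc2c(Br)cccc2Br)cc1`: > 100000 nM (a limit)
- compound 3 `CCCCOc1ccc(C(=O)NNc2c(Br)cccc2Br)cc1`: > 100000 nM (a limit)

Compound 3 has no numerical value, only a limit, and the same holds for the other two compounds. The shared position is the limit of > 100000 nM in this assay, at which 3 of the 3 values shown sit.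

Compound 4 `CCc1ccc(C(=O)NNc2c(Br)cccc2Br)cc1` follows from compound 3 by one change: ethyl in place of butoxy on an aromatic carbon. Ethyl replaces butoxy on an aromatic carbon, para to a large group.

Within the data shown here, three measured steps bear on this change, though all of them alter only the chain on the oxygen: a step that the two limits leave unreadable from compound 1 to compound 2, a step that the two limits leave unreadable from compound 1 to compound 3 and a step that the two limits leave unreadable from compound 2 to compound 3. None gives a size, and none removes the oxygen. Among the measured compounds shown here, no step of definite size or direction is therefore expected in this assay, and another limit is the likeliest report for compound 4 because of the limit of > 100000 nM in this assay, at which 3 of the 3 values shown sit. The expected step is a step that the limit leaves unreadable from compound 3 to compound 4.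

Compound 4 is expected at 120000 nM, with an estimated range of 50000 nM to 250000 nM.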

Compound 4, half-maximal cytotoxic concentration: > 100000 nM
Compound 4: no number, only a limit (the forecaster's own chance of this, stated with the estimate: 85%); the middle value lies beyond the limit too.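

In this assay, among these compounds, compound 4 gives > 100000 nM, a limit and not a number, so no step linking it to compound 1, compound 2 or compound 3 can be read. The compounds shown leave open how far any of the four lies beyond this limit, and which change to the shared core, if any, would yield a measurable value.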